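Swapping Hydroxy for Fluoro Where Only Limits Are Known

The source may report more compounds than this note shows. Statements on the series, on what has been measured and on what is new or still open speak of the compounds shown alone.

In an ADME assay on HepG2 cells (Homo sapiens) for cytotoxicity, read by CellTiter-Glo and resazurin assay, with a stated time of 72 h (a higher number here means that more compound is needed for the effect, a lower number that less compound is needed), three compounds built on a shared core have so far returned only limits, not numbers. Compound 1 `CC(C)N(Cc1cccc(OCCCCCC(=O)O)c1)C(=O)c1ccc(-c2cccc(-c3ccccc3)c2)cc1` carries a phenyl group at the place that varies and gives > 26000 nM as a limit. Compound 2 `CCOc1cccc(-c2ccc(C(=O)N(Cc3cccc(OCCCCCC(=O)O)c3)C(C)C)cc2)c1` carries ethoxy there and gives > 20800 nM as a limit. Compound 3 `CC(C)N(Cc1cccc(OCCCCCC(=O)O)c1)C(=O)c1ccc(-c2cccc(O)c2)cc1` carries hydroxy there and gives > 26000 nM as a limit, so it stands with the other two and has no number of its own.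

Compound 4 `CC(C)N(Cc1cccc(OCCCCCC(=O)O)c1)C(=O)c1ccc(-c2cccc(F)c2)cc1` differs from compound 3 in one place, with fluoro in place of hydroxy on an aromatic carbon and 3-hydroxyphenyl becoming 3-fluorophenyl.

Three measured changes at this same place bear on the swap. They are a step that the two limits leave unreadable from compound 1 to compound 3 and a step that the two limits leave unreadable from compound 2 to compound 3 and also a step that the two limits leave unreadable from compound 1 to compound 2 in the same series. None has a readable size, yet phenyl, ethoxy and hydroxy all end in limits.

Because compound 3 sits at the limit > 26000 nM no step beyond the usual scatter is expected in this assay for this swap. The expected outcome is a number no higher from compound 3 to compound 4 (the limit leaves the size open) in this estimate. For compound 4 the estimated half-maximal effective concentration is 26000 nM within a range of 15000 nM to 50000 nM and another limit is the likeliest report.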

Compound 4, half-maximal effective concentration: > 26000 nM
Compound 4: no number, only a limit; the forecaster's own chance of this, stated with the estimate: 85%; the middle value sits exactly at the limit.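

In this assay compound 4 gives > 26000 nM, which is a limit and not a number. No new step can be read between compound 4 and compound 1, compound 2 or compound 3, as all four values are limits. The compounds shown leave open what concentration of each gives the half-maximal effect, and whether the group at this place changes it.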